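The source may report more compounds than this note shows. Statements on the series, on what has been measured and on what is new or still open speak of the compounds shown alone.

In a functional assay on T47D cells (Homo sapiens) for cytotoxicity, read by MTT assay, with a stated time of 2 days (a higher number here means a weaker inhibitor, a lower number a stronger inhibitor), compound 1 `Cc1cccc(-c2nc3cc(C)ccc3c(=O)[nH]2)c1` gives > 50000 nM, which is a limit of the assay and not a number. Compound 2 `Cc1ccc2nc(-c3ccccc3C(F)(F)F)[nH]c(=O)c2c1` gives > 50000 nM, which is likewise a limit, so no actual number is available for it. The whole picture so far is the limit of > 50000 nM in this assay, at which 2 of the 2 values shown sit. Compound 3 `Cc1ccc2nc(-c3ccccc3OC(F)(F)F)[nH]c(=O)c2c1` keeps the shared core of compound 2 but has trifluoromethoxy in place of trifluoromethyl on an aromatic carbon, ortho to a large group: trifluoromethoxy in place of trifluoromethyl on an aromatic carbon. Within the data shown here, no step between measured compounds is available to show how large such a change might be. Because compound 2 gives > 50000 nM the expectation in this assay is for no step beyond the usual scatter, and the assay may again report only a limit. The estimate amounts to a number no higher from compound 2 to compound 3 (the limit leaves the size open), an expected step of little or no size. For compound 3 the expected value is 50000 nM, with an estimated range from 20000 nM to 100000 nM.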

Compound 3, half-maximal inhibitory concentration: > 50000 nM
Compound 3 gave a limit, no number (the forecaster's own chance of this, stated with the estimate: 75%); the middle value sits exactly at the limit.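

Compound 2 and compound 3 both give only a limit in this assay, not a number, so no step can be read for trifluoromethoxy in place of trifluoromethyl. The compounds shown leave open whether any change on the shared core would give a real number in this assay, because every value so far is a limit: the limit of > 50000 nM in this assay, at which 3 of the 3 values shown sit.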